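The source may hold more compounds than are shown below. What is called first, only, known or untested is meant among the compounds shown, and "the series" means these compounds.

Compound 1 `O=C(NCc1ccc(NC(=O)c2cc(-c3ccccc3)ccc2N2CCCC2)cc1)OCc1cccnc1` was tested in a functional assay on SGC-7901 cells (Homo sapiens) for inhibition, read by MTT assay, with a stated time of 72 h; a higher number here means a weaker inhibitor, a lower number a stronger inhibitor. There compound 1 gives > 100000 nM, which is a limit of the assay and not a number. Among the compounds with values here, compound 2 `Cc1cccc(C(=O)Nc2ccc(CNC(=O)OCc3cccnc3)cc2)c1N1CCCC1`, the only other compound measured, gives > 100000 nM, and this too is a limit. Together the two results amount to the limit of > 100000 nM in this assay, at which 2 of the 2 values shown sit, so neither compound has yet yielded a number, and no step between measured compounds is available as a guide.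

Compound 3 `O=C(NCc1ccc(NC(=O)c2cc(Br)ccc2N2CCCC2)cc1)OCc1cccnc1` keeps the core of compound 1 and differs in one place, with bromo in place of phenyl on an aromatic carbon, meta to a large group and para to a pyrrolidin-1-yl group: bromo in place of phenyl on an aromatic carbon. With only limits to go on, no step beyond the scatter is expected in this assay, in either direction, and compound 3 will most likely also be reported as a limit. The estimated step is a number no higher from compound 1 to compound 3 (the limit leaves the size open). Compound 3 is expected at about 100000 nM, with an estimated range from 30000 nM to 300000 nM.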

Compound 3, half-maximal inhibitory concentration: > 100000 nM
Compound 3: only a limit was reported; the forecaster's own chance of this, stated with the estimate: 70%; the middle value sits exactly at the limit.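

In this assay compound 3 gives > 100000 nM, a limit of the assay and not a number. No step can therefore be read between compound 1 and compound 3, and the result only adds to this: the limit of > 100000 nM in this assay, at which 3 of the 3 values shown sit.

The compounds shown leave open how phenyl and bromo compare in this assay, and what any group on the shared core does there.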